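Swapping a Diol Side Chain for a Carboxylic Acid

The source may report more compounds than this note shows. Statements on the series, on what has been measured and on what is new or still open speak of the compounds shown alone.

Compound 2 `CCn1c(C(=O)N[C@H](CO)CCO)ccc1C(CC)(CC)c1ccc(OCS(=O)(=O)c2ccccc2)c(C)c1` gives 15900 nM in a functional assay on BXPC-3 cells (Homo sapiens) for antiproliferative activity, read by MTT assay, with a stated time of 24 h (a lower number here means a stronger inhibitor, a higher number a weaker inhibitor), the larger of the two numbers shown, yet within the scatter of compound 1 `CCn1c(C(=O)N[C@@H](CO)C(C)C)ccc1C(CC)(CC)c1ccc(OCS(=O)(=O)c2ccccc2)c(C)c1`, which gives 13200 nM in this assay. For the measured compounds named here, the single measured step, a 1.2-fold higher number from compound 1 to compound 2 (0.08 log units; within the scatter), changed the group on the amide nitrogen without a real shift. Compound 3 `CCn1c(C(=O)N[C@@H](C(=O)O)C(C)C)ccc1C(CC)(CC)c1ccc(OCS(=O)(=O)c2ccccc2)c(C)c1` carries 1-carboxy-2-methylpropyl in place of 3-hydroxy-1-(hydroxymethyl)propyl on an amide-type nitrogen. Going by the values given here, no measured step exchanges a hydroxymethyl for a carboxy group, so guidance is thin; the expected step is a 1.0-fold higher number from compound 2 to compound 3 (0.00 log units; within the scatter), nothing beyond the scatter. Compound 3 is estimated at 16000 nM, within a range from 5000 nM to 50000 nM.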

Compound 3, half-maximal inhibitory concentration: 13900 nM
Compound 3: the middle estimate sits 1.2-fold (0.06 log units) above what was measured, within the range that was stated.
By their numbers in this assay, from the lowest: compounds 1, 3 and 2 (each within the scatter of the next).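

Carboxy in place of hydroxymethyl on the saturated chain carbon bound to the amide-type nitrogen now has a direct reading (a 1.1-fold higher number from compound 1 to compound 3 (0.02 log units; within the scatter)). The wider exchange, 1-carboxy-2-methylpropyl in place of 3-hydroxy-1-(hydroxymethyl)propyl, also leaves the number within the scatter (a 1.1-fold lower number from compound 2 to compound 3 (0.06 log units; within the scatter)), so all three groups at this place read alike in this assay. No supporting measurement is available to explain this flat result. Going by these compounds, whether an amine or a longer chain on this nitrogen would read differently remains open, as does whether any group here can move the number beyond the scatter.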